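Changing the Ether Substituent on the Shared Core

A few compounds are considered here, and "the series" means these few. Any claim that something is new, unique, unknown or untested is made for them only; others in the source may bear on it.

Measured compounds:
- Compound 1, `CCCCN(C)c1nc(C(C)(C)C)ccc1CNC(=O)C(C)c1ccc(NS(C)(=O)=O)c(F)c1`, 1.2 nM
- Compound 2, `CC(C(=O)NCc1ccc(C(C)(C)C)nc1OC1CCCC1)c1ccc(NS(C)(=O)=O)c(F)c1`, 1.5 nM

Both compounds were tested in an assay on cells for antagonist activity at transient receptor potential cation channel subfamily V member 1 (Homo sapiens), read by FLIPR and calcium flux, with a stated time of 6 min; a higher number here means a weaker inhibitor, a lower number a stronger inhibitor. Compound 2 gives 1.5 nM, the higher of the two numbers shown, while compound 1 gives 1.2 nM; the step of a 1.3-fold higher number from compound 1 to compound 2 (0.10 log units; within the scatter) is within the scatter, so the two cannot be told apart.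

Compound 3, `COCCCOc1nc(C(C)(C)C)ccc1CNC(=O)C(C)c1ccc(NS(C)(=O)=O)c(F)c1`, has not yet been measured. It differs from compound 2 in one place: 3-methoxypropyl in place of cyclopentyl on an oxygen on an aromatic ring. Going by the values given here, the only measured step that bears on this position, a 1.3-fold higher number from compound 1 to compound 2 (0.10 log units; within the scatter), shows that exchanging one substituent on this part of the shared core for another of similar size leaves the number essentially unchanged. Among the compounds with values here, no measured step covers an open chain carrying a second oxygen at this site, so the expectation rests on that single comparison. Compound 3 is therefore expected to stay close to compound 2, with at most a small step, a 2.0-fold higher number from compound 2 to compound 3 (0.30 log units; within the scatter), toward a higher number. The estimate for compound 3 is 3 nM, expected to fall between 1 nM and 10 nM.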

Compound 3, inhibition constant: 5.6 nM
Compound 3: middle estimate off by 1.9-fold (0.27 log units), on the low side; measured number inside the range.
By their numbers in this assay, from the lowest: compounds 1 and 2 (each within the scatter of the next); then compound 3.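

In this assay, the earlier pair suggested that this position tolerates exchange freely, but it does respond to the group it carries: the change from cyclopentyl gives a 3.7-fold higher number from compound 2 to compound 3 (0.57 log units; beyond the scatter), and the exchange of butyl(methyl)amino for 3-methoxypropoxy gives a 4.7-fold higher number from compound 1 to compound 3 (0.67 log units; beyond the scatter). Both steps are modest but beyond the scatter, and cyclopentyl and 3-methoxypropyl have the same count of heavy atoms, so that count alone does not set the number at this site. Nothing measured here explains the loss of potency.

This change removes the ring and adds the chain oxygen at once, so these compounds cannot show which of the two matters. A plain butyl ether on the same oxygen, or a chain ending in an amine, would help to separate them.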